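The source may report more compounds than this note shows. Statements on the series, on what has been measured and on what is new or still open speak of the compounds shown alone.

Measured compounds:
Compound 1 `O=C(O)c1ccc(-c2cnc(C(=O)CCc3ccc(-c4ccccc4)cc3)o2)nc1`, 14 nM
Compound 2 `COC(=O)c1cccc(-c2cnc(C(O)CCc3ccc(-c4ccccc4)cc3)o2)n1`, 9000 nM
Compound 3 `COC(=O)c1cccc(-c2cnc(C(=O)CCc3ccc(-c4ccccc4)cc3)o2)n1`, 1.2 nM

In an assay for inhibition of Fatty-acid amide hydrolase 1 (Rattus norvegicus) (on this read-out lower numbers stand for stronger inhibition and higher numbers for weaker inhibition), compound 3 gives 1.2 nM and compound 1 gives 14 nM. The two differ by 5-carboxypyridin-2-yl in place of 6-(methoxycarbonyl)pyridin-2-yl on an aromatic carbon, and the step of a 12-fold higher number from compound 3 to compound 1 (1.07 log units; beyond the scatter). How the core of compound 2 differs from that of compound 3 is not broken down here; in this assay compound 2 gives 9000 nM, the highest of the three numbers. Compound 4 `O=C(O)c1ccc(-c2cnc(C(O)CCc3ccc(-c4ccccc4)cc3)o2)nc1` is not yet measured; it differs from compound 2 by 5-carboxypyridin-2-yl in place of 6-(methoxycarbonyl)pyridin-2-yl on an aromatic carbon, at the same place, so it is the same change as between compound 3 and compound 1. Because a 12-fold higher number from compound 3 to compound 1 (1.07 log units; beyond the scatter), a weakening of similar size is expected for compound 4, though a core already this weak may not carry the full step, so the estimate is a 6.7-fold higher number from compound 2 to compound 4 (0.82 log units; beyond the scatter). Compound 4 is expected to give about 60000 nM, between 15000 nM and 300000 nM.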

Compound 4, inhibition constant: 10000 nM
Beside the measured number, compound 4's estimate is 6.0-fold (0.78 log units) above it; the measured number lies below the stated range.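

In this assay, putting 5-carboxypyridin-2-yl in place of 6-(methoxycarbonyl)pyridin-2-yl on the second core gives a 1.1-fold higher number from compound 2 to compound 4 (0.05 log units; within the scatter), so no effect of the change can be seen there. The size of the step therefore did not carry over from one core to the other: the same change on two cores in this assay, a 12-fold higher number (1.07 log units; beyond the scatter) from compound 3 to compound 1 and a 1.1-fold higher number (0.05 log units; within the scatter) from compound 2 to compound 4, 11-fold (1.02 log units) apart, beyond the scatter of two such steps. This shows that, for these two pairs, the effect of the change depends on the core it is made on, but it does not show why, and two pairs cannot predict the step on any further core.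

Still open, as far as these compounds go, is how an amide or a nitrile in place of the carboxylic acid would behave on each core. The compounds shown also leave open whether a core with an amine in place of the alcohol would carry the step.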